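Halogen exchange on compound 3

A few compounds are considered here, and "the series" means these few. Any claim that something is new, unique, unknown or untested is made for them only; others in the source may bear on it.

compound 1 `COc1cc2ncnc(Nc3cccc(Br)c3)c2cc1OCCCN1CCNCCNCCNCC1`: 14700 nM
compound 2 `COc1cc2ncnc(Nc3ccc(C#N)cc3F)c2cc1OCCCN1CCNCCNCCNCC1`: > 50000 nM, a limit of the assay
compound 3 `COc1cc2ncnc(Nc3cccc(Br)c3)c2cc1OCCCN1CCNCCNCC1`: 34300 nM

In a functional assay on A549 cells (Homo sapiens) for antiproliferative activity, read by MTT assay, with a stated time of 72 h (on this read-out lower numbers stand for stronger inhibition and higher numbers for weaker inhibition), compound 3 gives 34300 nM, the higher of the two actual numbers, and compound 1 gives 14700 nM. Compound 2 reports only a limit.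

Compound 4 `COc1cc2ncnc(Nc3cccc(Cl)c3)c2cc1OCCCN1CCNCCNCC1` carries chloro in place of bromo on an aromatic carbon, meta to a large group: chloro in place of bromo on an aromatic carbon.

Going by the values given here, two measured steps bear on this only indirectly. The ring change, a 2.3-fold higher number from compound 1 to compound 3 (0.37 log units; beyond the scatter), leaves the bromo group untouched. The other, an at least 3.4-fold higher number from compound 1 to compound 2 (0.53 log units; beyond the scatter), replaces the whole 3-bromophenyl group and ends at a limit. Among the compounds with values here, no measured step exchanges one halogen for another, so neither size carries over directly. Taking compound 3 at 34300 nM as the anchor, no step beyond the scatter is expected in this assay. The expected change is a 1.0-fold higher number from compound 3 to compound 4 (0.01 log units; within the scatter). Compound 4 is estimated at 35000 nM, with an expected range of 16000 nM to 50000 nM.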

Compound 4, half-maximal inhibitory concentration: > 50000 nM
Compound 4 gave a limit, no number; the forecaster's own chance of this, stated with the estimate: 20%; middle value at least 1.4-fold (0.15 log units) away from the limit.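

In this assay, the only halogen exchange shown, chloro in place of bromo on this aromatic carbon, gives an at least 1.4-fold higher number from compound 3 to compound 4 (0.16 log units; that floor lies within the scatter). That floor lies within the scatter, so the exchange is not shown to weaken the compound beyond it, and the true size of the step cannot be read: the limit of > 50000 nM in this assay, at which 2 of the 4 values shown sit.

The new step adds a second case to an at least 3.4-fold higher number from compound 1 to compound 2 (0.53 log units; beyond the scatter), so both changes away from 3-bromophenyl shown here end at a limit, on two different large rings.

From the compounds shown here alone, how far compound 4 lies past its limit remains open, as does whether 3-chlorophenyl would give a readable number on the large ring of compound 1. Also open, going by these compounds, is how iodo or methyl on this aromatic carbon would compare with bromo.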